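Methoxy in place of hydrogen on the shared core

The source may report more compounds than this note shows. Statements on the series, on what has been measured and on what is new or still open speak of the compounds shown alone.

Measured so far in an assay for displacement of a labelled ligand from Nicotinic acetylcholine receptor alpha8 subunit (Periplaneta americana), read by scintillation counting, with a stated time of 2 h, at 24 degrees C; on this read-out lower numbers stand for stronger inhibition and higher numbers for weaker inhibition:
compound 1 `C(=C1\CCN=C1c1cccnc1)\c1ccccc1`, > 10000 nM
compound 2 `Oc1ccc(/C=C2\CCN=C2c2cccnc2)cc1`, 310 nM
compound 3 `Oc1cccc(/C=C2\CCN=C2c2cccnc2)c1`, > 10000 nM

Compound 1 sits at the limit of this assay, at > 10000 nM, which is a limit and not a number. Compound 3 also sits at that limit, at > 10000 nM. Compound 2 is the only one of the three with a measured number, 310 nM.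

The change to compound 4 `COc1ccccc1/C=C1\CCN=C1c1cccnc1` is methoxy in place of hydrogen on an aromatic carbon, on an aromatic carbon of a six-membered aromatic ring of carbon only, ortho to a large group.

Going by the values given here, two measured steps bear on this. The step of an at least 32-fold lower number from compound 1 to compound 2 (1.50 log units; beyond the scatter) shows a large gain from a hydroxy group at one position. The step that the two limits leave unreadable from compound 1 to compound 3 shows no readable gain from the same group at another position, because of the limit of > 10000 nM in this assay, at which 2 of the 3 values shown sit. Compound 4 carries a methoxy, with no hydrogen-bond donor, at a third position. The evidence therefore gives no ground to expect a step beyond the scatter, and compound 4 is expected to stay near the limit.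

Compound 4 is estimated at 15000 nM, between 3000 nM and 60000 nM. That estimate means a step that the limit leaves unreadable from compound 1 to compound 4, with the limit the more probable outcome.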

Compound 4, half-maximal inhibitory concentration: > 10000 nM
Compound 4: a limit, no number; the forecaster's own chance of this, stated with the estimate: 65%; the middle value is on the limit's open side.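

No step from compound 1 to compound 4 can be read, because both values are limits and not numbers: the limit of > 10000 nM in this assay, at which 3 of the 4 values shown sit.

The compounds shown leave open whether methoxy in place of hydrogen on this aromatic carbon changes the read-out at all, and by how much.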